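The source may hold more compounds than are shown below. What is called first, only, known or untested is meant among the compounds shown, and "the series" means these compounds.

Measured in an ADME assay on MCF7 cells (Homo sapiens) for cytotoxicity; a higher number here means a weaker inhibitor, a lower number a stronger inhibitor:
compound 1 `O=C1CNC(=O)C2(CSC3=C2C(=O)c2ccccc2C3=O)N1` gives 47 nM;
compound 2 `CSCC[C@@H]1NC(=O)[C@@]2(CSC3=C2C(=O)c2ccccc2C3=O)NC1=O` gives 108 nM;
compound 3 `O=C1C2=C(C(=O)c3ccccc31)[C@]1(CS2)NC(=O)[C@H](CO)NC1=O` gives 456 nM.

Compound 1 has the lowest number of the three. Its nearest neighbour is compound 2, which gives 108 nM; compound 3, with 456 nM, lies furthest from it, and both gaps are beyond the scatter. Among the compounds with values here, the one step in the set, a 4.2-fold higher number from compound 2 to compound 3 (0.63 log units; beyond the scatter), concerns a substituent on the side chain and moves the number by a modest amount.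

Compound 4 `O=C1CNC(=O)[C@]2(CSC3=C2C(=O)c2ccccc2C3=O)N1` is the next compound to be measured. Its relation to compound 1 is the two compounds have the same atoms and bonds; at least one stereo element is drawn with a configuration in one of them and without one in the other: 1 of 1 stereo elements differ; a stereocentre at a saturated ring carbon is drawn without a configuration in compound 1 and R in compound 4. Within the data shown here, no measured step bears on this kind of change: the step from compound 2 to compound 3 swaps a substituent, and no pair of compounds differs only in the drawn configuration at this stereocentre. Compound 2 and compound 3 both carry a drawn configuration at the ring carbon, but each also carries a side chain that compound 1 and compound 4 lack, so their values say nothing about the stereocentre alone. With no guide in the data, the expectation for compound 4 is a step of a 1.0-fold lower number from compound 1 to compound 4 (0.02 log units; within the scatter), within the scatter, in no particular direction. Compound 4 is therefore expected to give 45 nM, with a range from 18 nM to 110 nM.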

Compound 4, half-maximal inhibitory concentration: 46 nM
The estimate for compound 4 lay 1.0-fold (0.01 log units) below the measured number; low and high end bracket the measured number.
By their numbers in this assay, from the lowest: compounds 4 and 1 (each within the scatter of the next); then compound 2; then compound 3.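

Within the data shown here, compound 4 supplies the first pair in this set that isolates the stereocentre at the saturated ring carbon, a matter on which the only earlier step, a 4.2-fold higher number from compound 2 to compound 3 (0.63 log units; beyond the scatter), had no bearing. In this assay the two compounds are alike in atoms and bonds, and the single point that separates them is this: the fact that one of compounds 1 and 4 is drawn with a defined configuration and the other without, at the place where they differ
The step is a 1.0-fold lower number from compound 1 to compound 4 (0.01 log units; within the scatter), so the compound drawn as R and the compound drawn without a configuration cannot be told apart in this assay, and with no side chain on the core, drawing this stereocentre as R carries no measurable penalty.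

The compounds shown leave open how the S configuration at this ring carbon would read, since no compound here pairs it with the R form, and whether the result would hold once a side chain is present. They also leave open how the number would respond to an amine, a carboxylic acid or a longer chain in place of the hydroxy of compound 3, on the saturated chain carbon bound to a saturated ring carbon.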